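Aryl change on the core: compound 2 to compound 3

The source may report more compounds than this note shows. Statements on the series, on what has been measured and on what is new or still open speak of the compounds shown alone.

Measured so far:
compound 1 `CC(C(=O)NCc1ccc(C(F)(F)F)nc1-c1ccccc1)c1ccc(NS(C)(=O)=O)c(F)c1`, 6.4 nM
compound 2 `CC(C(=O)NCc1ccc(C(F)(F)F)nc1-c1ccc(Cl)c(Cl)c1)c1ccc(NS(C)(=O)=O)c(F)c1`, 0.9 nM

Going by the values given here, in an assay on CHO cells for antagonist activity at transient receptor potential cation channel subfamily V member 1 (Homo sapiens), read by FLIPR (on this read-out lower numbers stand for stronger inhibition and higher numbers for weaker inhibition), compound 2 holds the lowest of the two numbers; the nearest is compound 1, and the only step between them, a 7.1-fold lower number from compound 1 to compound 2 (0.85 log units; beyond the scatter), is the one that bears on the change here. Compound 3 `COc1ccc(-c2nc(C(F)(F)F)ccc2CNC(=O)C(C)c2ccc(NS(C)(=O)=O)c(F)c2)cc1OC` differs from compound 2 by 3,4-dimethoxyphenyl in place of 3,4-dichlorophenyl on an aromatic carbon. Among the compounds with values here, no measured pair shows the dimethoxyphenyl itself, so the expectation rests on that single step alone. The number for compound 3 in this assay is expected to move up, by a 4.4-fold higher number from compound 2 to compound 3 (0.65 log units; beyond the scatter). Compound 3 is thus estimated at 4 nM, within 1 nM to 20 nM.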

Compound 3, inhibition constant: 25.6 nM
Compound 3: middle estimate off by 6.4-fold (0.81 log units), on the low side; the measured number lies above the stated range.
By their numbers in this assay, from the lowest: compound 2; then compound 1; then compound 3.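

In this assay, this aryl position on the shared core is sensitive to the identity of its substituents: 3,4-dimethoxyphenyl in place of 3,4-dichlorophenyl gives a 28-fold higher number from compound 2 to compound 3 (1.45 log units; beyond the scatter) and is a large change. Substitution alone therefore brings no gain here, since 3,4-dimethoxyphenyl in place of phenyl gives a 4.0-fold higher number from compound 1 to compound 3 (0.60 log units; beyond the scatter) and the two disubstituted rings fall on opposite sides of compound 1. Nothing on hand explains this reversal.

Open, on these data alone, is whether one substituent alone would carry either shift, and how an amine or a carboxylic acid on this phenyl would place against compound 1.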